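Working notes: replacing phenoxy with tert-butyl

A few compounds are considered here, and "the series" means these few. Any claim that something is new, unique, unknown or untested is made for them only; others in the source may bear on it.

Measured in a functional assay on HT-29 cells (Homo sapiens) for inhibition, read by sulforhodamine B assay, with a stated time of 48 h (on this read-out higher numbers stand for weaker inhibition of growth and lower numbers for stronger inhibition of growth), so far
- compound 1 `O=C(CCl)NC(=O)Nc1ccc(C2CCCCC2)cc1` gives 2300 nM
- compound 2 `O=C(CCl)NC(=O)Nc1ccc(-c2ccccc2)cc1` gives 2300 nM
- compound 3 `O=C(CCl)NC(=O)Nc1ccc(Oc2ccccc2)cc1` gives 3600 nM

Compound 3 stands within the scatter of both others, with a 1.6-fold higher number from compound 1 to compound 3 (0.19 log units; within the scatter) and a 1.6-fold higher number from compound 2 to compound 3 (0.19 log units; within the scatter) as its steps. Within the data shown here, compound 4 `CC(C)(C)c1ccc(NC(=O)NC(=O)CCl)cc1` follows from tert-butyl in place of phenoxy on an aromatic carbon as the single change. The remaining step at this place is also small, with no change at the digits printed from compound 1 to compound 2 (within the scatter) on record, so cyclohexyl, phenyl and phenoxy are not told apart here. Among the measured compounds shown here, no measured compound carries tert-butyl or lacks a ring at this place, so the expectation is an extrapolation. No step beyond the scatter is expected in this assay for this change. The expected step is a 1.2-fold lower number from compound 3 to compound 4 (0.08 log units; within the scatter) on this estimate. The estimate for compound 4 is 3000 nM with 1500 nM to 6000 nM as its expected range.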

Compound 4, concentration for 50% growth inhibition: 3300 nM
Compound 4: middle estimate off by 1.1-fold (0.04 log units), on the low side; measured number inside the range.
By their numbers in this assay, from the lowest: compounds 1, 2, 4 and 3 (each within the scatter of the next).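

In this assay, tert-butyl, which has no ring, cannot be told apart from the three ring-bearing groups at this place (a 1.1-fold lower number from compound 3 to compound 4 (0.04 log units; within the scatter); a 1.4-fold higher number from compound 2 to compound 4 (0.16 log units; within the scatter); a 1.4-fold higher number from compound 1 to compound 4 (0.16 log units; within the scatter)). Across these four compounds, a six-membered aromatic or saturated ring on this aromatic carbon is therefore not required for a number in this range. Nothing at hand explains this flat result. Still open, going by these compounds, is whether an amine, a carboxylic acid or a longer chain at this place would stay within the same range. Equally open, on these data alone, is whether a plain hydrogen there would do so.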